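A few compounds are considered here, and "the series" means these few. Any claim that something is new, unique, unknown or untested is made for them only; others in the source may bear on it.

Compound 1 `C=C(Br)C(=O)Nc1ccc(/C=C2\SC(=O)N(Cc3ccccc3)C2=O)cc1`, in a functional assay on HeLa cells (Homo sapiens) for cytotoxicity, read by cell counting, with a stated time of 4 days (on this read-out lower numbers stand for stronger inhibition and higher numbers for weaker inhibition), compound 1 gives 1000 nM.
Compound 2 `C=C(Br)C(=O)Nc1ccc(/C=C2\SC(=O)N(C)C2=O)cc1`, in this assay compound 2 gives 870 nM.
Compound 3 `CN1C(=O)S/C(=C\c2ccc(N)cc2)C1=O`, in this assay compound 3 gives 97000 nM.

Compounds 1 and 2 share one core and differ in a single change, (phenyl in place of hydrogen on a saturated chain carbon bound to an amide-type nitrogen in a ring). That change made a step of a 1.1-fold higher number from compound 2 to compound 1 (0.06 log units; within the scatter), so the two values are indistinguishable here. Compound 3 belongs to a second core, which differs from the first by hydrogen in place of (1-bromoethenyl)carbonyl on a nitrogen on an aromatic ring; that difference gave a step of a 110-fold higher number from compound 2 to compound 3 (2.05 log units; beyond the scatter).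

Compound 4 `Nc1ccc(/C=C2\SC(=O)N(Cc3ccccc3)C2=O)cc1` has not yet been measured. It is made from compound 3 by phenyl in place of hydrogen on a saturated chain carbon bound to an amide-type nitrogen in a ring, at a place described in exactly the same words as in the first pair, so the change is the same one. On the first core this change moved the number only within the scatter, with the step of a 1.1-fold higher number from compound 2 to compound 1 (0.06 log units; within the scatter). Resting on that single precedent, the step from compound 3 to compound 4 in this assay is expected to be a 1.0-fold higher number from compound 3 to compound 4 (0.01 log units; within the scatter). Compound 4 is therefore estimated at 100000 nM, plausibly between 40000 nM and 250000 nM.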

Compound 4, half-maximal inhibitory concentration: 46000 nM
Estimate against measurement, compound 4: 2.2-fold (0.34 log units) above; low and high end bracket the measured number.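

Putting benzyl in place of methyl on the core of compound 3 gave a 2.1-fold lower number from compound 3 to compound 4 (0.32 log units; beyond the scatter) in this assay, a modest step, while the same change on the first core stayed within the scatter, and the two steps agree within what repeated measurements allow: the same change on two cores in this assay, a 1.1-fold higher number (0.06 log units; within the scatter) from compound 2 to compound 1 and a 2.1-fold lower number (0.32 log units; beyond the scatter) from compound 3 to compound 4, 2.4-fold (0.38 log units) apart, within the scatter of two such steps
Removing the (1-bromoethenyl)carbonyl group, which leaves a free amine on the aromatic ring, gave a 46-fold higher number from compound 1 to compound 4 (1.66 log units; beyond the scatter), and this large step also carried over from one core to the other: the same change on two cores in this assay, a 110-fold higher number (2.05 log units; beyond the scatter) from compound 2 to compound 3 and a 46-fold higher number (1.66 log units; beyond the scatter) from compound 1 to compound 4, 2.4-fold (0.38 log units) apart, within the scatter of two such steps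
So, within these four compounds, each change had much the same effect whichever form the other part took, but this rests on one pair of steps per change and does not show that either change would carry over to a further core, nor why the numbers move.

From the compounds shown here alone, it remains open whether a plain acetyl group on that nitrogen would keep the lower numbers of compound 1 and compound 2, which would show whether the bromine is needed. Going by these compounds, it is also open whether a longer chain such as propyl, in place of methyl or benzyl, would follow the same pattern.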